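Swapping the aryl ring on the acrylic acid of compound 1

The compounds below may be only part of what the source reports. "The series", "measured", "known", "first", "only" and "open" are said of these compounds alone.

For the measured compounds named here, compound 1 `CC(=O)n1cc(/C=C(/C(=O)O)c2ccc(Cl)cc2)c2cc(OCc3ccccc3)ccc21` is the only member of this small series with a number: in a functional assay on A549 cells (Homo sapiens) for cytotoxicity, read by MTT assay, with a stated time of 72 h (a lower number here means a stronger inhibitor, a higher number a weaker inhibitor), compound 1 gives 52300 nM, a weak result. Compound 2 `O=C(O)/C(=C/c1c[nH]c2ccc(OCc3ccccc3)cc12)c1ccccc1` was run in this assay, where compound 2 gives "not determined" (no result reported), so no number is available for it. Compound 3 `COc1cccc(/C(=C\c2cn(C(C)=O)c3ccc(OCc4ccccc4)cc23)C(=O)O)c1` differs from compound 1 by 3-methoxyphenyl in place of 4-chlorophenyl on a double-bonded chain carbon bound to a carbonyl carbon and a double-bonded chain carbon. Going by the values given here, with no measured step of this kind to lean on, the change is expected to move the number no further than the usual scatter, in either direction, so the step of a 1.0-fold lower number from compound 1 to compound 3 (0.02 log units; within the scatter) is expected to be small. Compound 3 is therefore estimated at 50000 nM, within 15000 nM to 150000 nM.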

Compound 3, half-maximal inhibitory concentration: 45200 nM
Beside the measured number, compound 3's estimate is 1.1-fold (0.04 log units) above it; measured number inside the range.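

In this assay, 3-methoxyphenyl in place of 4-chlorophenyl on a double-bonded chain carbon bound to a carbonyl carbon and a double-bonded chain carbon gives a 1.2-fold lower number from compound 1 to compound 3 (0.06 log units; within the scatter). For the compounds shown here, this is the first measured step at this position, and it shows that this exchange of one substituted phenyl group for another leaves the two compounds within the scatter of each other. No supporting measurement bears on this result. Still open, as far as these compounds go, is whether a pyridine ring or an aminophenyl group at this position would move the number beyond the scatter.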